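The compounds below may be only part of what the source reports. "The series", "measured", "known", "first", "only" and "open" are said of these compounds alone.

Compound 2 `COc1ccc(NC(=O)Nc2nc(Sc3c[nH]c4ccccc34)cc(N3CCN(c4ccccn4)CC3)n2)cc1` gives 11400 nM in a functional assay on HepG2 cells (Homo sapiens) for inhibition, with a stated time of 72 h; a higher number here means a weaker inhibitor, a lower number a stronger inhibitor; compound 3 `O=C(Nc1ccccc1)Nc1nc(Sc2c[nH]c3ccccc23)cc(N2CCCC2)n1` gives 11400 nM in this assay, and compound 1 `COc1ccc(NC(=O)Nc2nc(Sc3c[nH]c4ccccc34)cc(N3CCCCC3)n2)cc1` gives 17100 nM. Compound 2 thus stands level with compound 3 at the digits shown, and both lie within the scatter of compound 1. Compound 4 `COc1ccc(NC(=O)Nc2nc(Nc3cc(OC)cc(OC)c3)cc(Sc3c[nH]c4ccccc34)n2)cc1` differs from compound 2 by (3,5-dimethoxyphenyl)amino in place of 4-(pyridin-2-yl)piperazin-1-yl on an aromatic carbon. Going by the values given here, the only measured step at this position is a 1.5-fold lower number from compound 1 to compound 2 (0.18 log units; within the scatter), which is within the scatter; compound 3, which differs from compound 2 in two places, sits at the same value as compound 2. Among the compounds with values here, no measured step here is beyond the scatter, so the expected change from compound 2 to compound 4 is none beyond the scatter, a 1.1-fold lower number from compound 2 to compound 4 (0.06 log units; within the scatter). Compound 4 is therefore estimated at 10000 nM, with a range of 3000 nM to 35000 nM.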

Compound 4, half-maximal inhibitory concentration: 17400 nM
Compound 4: middle estimate off by 1.7-fold (0.24 log units), on the low side; low and high end bracket the measured number.
By their numbers in this assay, from the lowest: compounds 2, 3, 1 and 4 (each within the scatter of the next).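

In this assay, (3,5-dimethoxyphenyl)amino in place of 4-(pyridin-2-yl)piperazin-1-yl gives a 1.5-fold higher number from compound 2 to compound 4 (0.18 log units; within the scatter), and in place of piperidin-1-yl it gives a 1.0-fold higher number from compound 1 to compound 4 (0.01 log units; within the scatter). This position therefore now carries an entering group with a hydrogen-bond donor and no non-aromatic ring, and compounds 1, 2 and 4 still stay within the scatter of one another. No measurement at hand bears on why these groups read alike. Still open, on these data alone, is whether a carboxylic acid or a primary amine at this position would give a step beyond the scatter.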